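Bithiophene sulfonamide in place of bromophenyl

The source may hold more compounds than are shown below. What is called first, only, known or untested is meant among the compounds shown, and "the series" means these compounds.

Two compounds of the series have been run in a functional assay on HepG2 cells for inhibition of squalene monooxygenase (Homo sapiens); a higher number here means a weaker inhibitor, a lower number a stronger inhibitor. Compound 1 `CCN(C/C=C/C#CC(C)(C)C)Cc1cccc(OCCN(C)S(=O)(=O)c2ccc(Br)cc2)c1` gives 330 nM, the higher of the two numbers. Compound 2 `CCN(C/C=C/C#CC(C)(C)C)Cc1cccc(OCCN(CC)S(=O)(=O)c2cccs2)c1` gives 90 nM in this assay, a lower number that lies beyond the scatter. Compound 3 `CCN(C/C=C/C#CC(C)(C)C)Cc1cccc(OCCN(C)S(=O)(=O)c2ccc(-c3cccs3)s2)c1` is not yet measured. It differs from compound 1 in one place: 5-(thiophen-2-yl)thiophen-2-yl in place of 4-bromophenyl on a sulfonyl sulfur. Within the data shown here, no measured pair shows this exact change, so its size is not known from the data. Compound 2 carries a five-membered aromatic ring with one hetero atom on its sulfonyl sulfur and gives 90 nM, which points toward a lower number for a sulfonamide of that kind, though compound 2 differs from compound 1 at the sulfonamide nitrogen as well. A modest step toward a lower number is expected, a 2.1-fold lower number from compound 1 to compound 3 (0.31 log units; beyond the scatter), with wide uncertainty. Compound 3 is estimated at 160 nM, within 50 nM to 500 nM.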

Compound 3, half-maximal inhibitory concentration: 10000 nM
The estimate for compound 3 lay 63-fold (1.80 log units) below the measured number, and the stated range ends below it.
By their numbers in this assay, from the lowest: compound 2; then compound 1; then compound 3.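

On the sulfonyl sulfur, the aromatic group strongly affects the result in this assay: 5-(thiophen-2-yl)thiophen-2-yl in place of 4-bromophenyl gives a 30-fold higher number from compound 1 to compound 3 (1.48 log units; beyond the scatter). This position therefore does not accept every aromatic replacement, and having five-membered aromatic rings with one hetero atom there does not by itself ensure a low number. No available evidence bears on the cause of this large step.

The compounds shown do not separate the effect of losing the 4-bromophenyl group from that of adding the second thiophene, and compound 2 cannot settle this, as it also differs at the sulfonamide nitrogen. A 5-chlorothiophen-2-yl group or a biphenyl-4-yl group on the sulfonyl sulfur, with the sulfonamide nitrogen of compound 1 kept, would help to separate ring type from group size.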